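The source may report more compounds than this note shows. Statements on the series, on what has been measured and on what is new or still open speak of the compounds shown alone.

Of the compounds shown here, three have been tested in an ADME assay on Huh-7 cells (Homo sapiens) for cytotoxicity; on this read-out higher numbers stand for lower toxicity in this test and lower numbers for higher toxicity in this test. Compound 1 `CN1CCN(CCCNCc2cn(-c3ccc([N+](=O)[O-])cc3)nc2-c2ccc(Cl)cc2)CC1` gives 3700 nM. Compound 3 `CN1CCN(CCCNCc2cn(-c3ccc(C(F)(F)F)cc3)nc2-c2ccc(Cl)cc2)CC1` gives 2500 nM and shares its core, and the difference between the two is trifluoromethyl in place of nitro on an aromatic carbon; the step in this assay was a 1.5-fold lower number from compound 1 to compound 3 (0.17 log units; within the scatter). Compound 2 `CCCN1CCC(CNCc2cn(-c3ccc([N+](=O)[O-])cc3)nc2-c2ccc(C(F)(F)F)cc2)CC1` gives 2300 nM in this assay; the difference between its core and the core of compound 1 is not broken down here. Compound 4 `CCCN1CCC(CNCc2cn(-c3ccc(C(F)(F)F)cc3)nc2-c2ccc(C(F)(F)F)cc2)CC1` has not yet been measured. It differs from compound 2 by trifluoromethyl in place of nitro on an aromatic carbon, the same change as that from compound 1 to compound 3. Because that step was a 1.5-fold lower number from compound 1 to compound 3 (0.17 log units; within the scatter), a similarly small step is expected for compound 4, namely a 1.4-fold lower number from compound 2 to compound 4 (0.13 log units; within the scatter). The estimate for compound 4 in this assay is therefore 1700 nM.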

Compound 4, half-maximal cytotoxic concentration: 1200 nM
Compound 4: middle estimate off by 1.4-fold (0.15 log units), on the high side, within the range that was stated.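

In this assay, the change from 4-nitrophenyl to 4-(trifluoromethyl)phenyl gives a 1.9-fold lower number from compound 2 to compound 4 (0.28 log units; within the scatter). Set beside the earlier case, the two cores agree as far as this test can tell: the same change on two cores in this assay, a 1.5-fold lower number (0.17 log units; within the scatter) from compound 1 to compound 3 and a 1.9-fold lower number (0.28 log units; within the scatter) from compound 2 to compound 4, 1.3-fold (0.11 log units) apart, within the scatter of two such steps. The change therefore carried over between these two cores with no detectable difference, but each step is itself within the scatter, so these results do not show that the change really moves the number at all, and two cores cannot speak for the whole series. The compounds shown leave open what other groups at this place would do, such as a nitrile or a carboxylic acid. As far as these compounds go, whether the same change behaves alike on a third core also remains open.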